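Swapping the aryl group on the triazole nitrogen

The compounds below may be only part of what the source reports. "The series", "measured", "known", "first", "only" and "open" are said of these compounds alone.

Measured so far:
Compound 1, `CCc1ccccc1-n1cc(COc2cccc(NC(=O)Nc3ccc(Cl)c(C(F)(F)F)c3)c2)nn1`: 3530 nM
Compound 2, `CC(C)c1cccc(-n2cc(COc3cccc(NC(=O)Nc4ccc(Cl)c(C(F)(F)F)c4)c3)nn2)c1`: 3250 nM
Compound 3, `O=C(Nc1cccc(OCc2cn(-c3cccc(Cl)c3)nn2)c1)Nc1ccc(Cl)c(C(F)(F)F)c1`: 2020 nM

All three were tested in a functional assay on HepG2 cells (Homo sapiens) for inhibition, read by MTT assay, with a stated time of 72 h; a lower number here means a stronger inhibitor, a higher number a weaker inhibitor. Compound 1 gives the highest of the three numbers, although its gaps to compound 2 (a 1.1-fold lower number from compound 1 to compound 2 (0.04 log units; within the scatter)) and to compound 3 (a 1.7-fold lower number from compound 1 to compound 3 (0.24 log units; within the scatter)) both lie within the usual scatter, so no ordering among them can be claimed.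

The next compound, compound 4 (`O=C(Nc1cccc(OCc2cn(-c3ccc(Cl)cc3)nn2)c1)Nc1ccc(Cl)c(C(F)(F)F)c1`), differs from compound 1 in one place: 4-chlorophenyl in place of 2-ethylphenyl on an aromatic nitrogen. Within the data shown here, the closest precedent is the step to compound 3, where a chlorophenyl also replaced the 2-ethylphenyl and the number fell only modestly (a 1.7-fold lower number from compound 1 to compound 3 (0.24 log units; within the scatter)); the step from compound 2 to compound 3, chloro in place of isopropyl (a 1.6-fold lower number from compound 2 to compound 3 (0.21 log units; within the scatter)), points the same way and is also small. Moving a chloro from one ring position to another has no precedent among these compounds, so compound 4 is expected to land near compound 3, with a 1.4-fold lower number from compound 1 to compound 4 (0.15 log units; within the scatter) as the estimated step from compound 1. Compound 4 is therefore estimated at 2500 nM, with a likely range from 1200 nM to 5000 nM.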

Compound 4, half-maximal inhibitory concentration: 2490 nM
For compound 4 the middle estimate is 1.0-fold (0.00 log units) above the measured one, within the range that was stated.
By their numbers in this assay, from the lowest: compounds 3, 4, 2 and 1 (each within the scatter of the next).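

Among these compounds, compound 4 gives the first direct look at where the chloro sits on this aryl ring: 4-chlorophenyl in place of 3-chlorophenyl (a 1.2-fold higher number from compound 3 to compound 4 (0.09 log units; within the scatter)) leaves no readable difference in this assay. The replacements of the alkyl-bearing rings also stay small, both for 4-chlorophenyl in place of 2-ethylphenyl (a 1.4-fold lower number from compound 1 to compound 4 (0.15 log units; within the scatter)) and for 4-chlorophenyl in place of 3-isopropylphenyl (a 1.3-fold lower number from compound 2 to compound 4 (0.12 log units; within the scatter)), so every step among these four compounds lies within the scatter, with no exception. Nothing measured here speaks to what lies behind this flat result.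

The compounds shown all carry an alkyl or chloro group on this ring, so they cannot tell whether any change on the aromatic nitrogen moves the number beyond the scatter. An amine or a carboxylic acid on the ring remains an open case.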